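The source may report more compounds than this note shows. Statements on the series, on what has been measured and on what is new or still open speak of the compounds shown alone.

Measured compounds in a functional assay on MCF7 cells (Homo sapiens) for cytotoxicity, read by MTT assay, with a stated time of 48 h; on this read-out lower numbers stand for stronger inhibition and higher numbers for weaker inhibition:
compound 1, `CCCCCCCCNC(=O)[C@@H](NC(=O)c1ccco1)[C@@H](C)O`, giving 91800 nM
compound 2, `CCCCCCCCCCCCCCNC(=O)[C@@H](NC(=O)c1ccco1)[C@@H](C)O`, giving 105000 nM
compound 3, `CCCCCCCCCCCCCCNC(=O)[C@@H](NC(=O)c1cc2ccccc2n1C)[C@@H](C)O`, giving 25700 nM

Compound 2 has the highest number of the three, though its gap to compound 1 is within the scatter: a 1.1-fold higher number from compound 1 to compound 2 (0.06 log units; within the scatter). Among the measured compounds shown here, the one step that goes beyond the scatter is a 4.1-fold lower number from compound 2 to compound 3 (0.61 log units; beyond the scatter), where the acyl group on the amine nitrogen is exchanged while the rest of the molecule stays fixed.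

Compound 4, `CCCCCCCCCCCCCCNC(=O)[C@@H](NS(=O)(=O)c1cccs1)[C@@H](C)O`, differs from compound 2 at that same position: (thiophen-2-yl)sulfonyl in place of (furan-2-yl)carbonyl on an amine nitrogen. For the measured compounds named here, no measured pair shows a carbonyl replaced by a sulfonyl, so the only guidance is that the step from compound 2 to compound 3 shows this position can shift the read-out modestly when the group on the amine nitrogen is changed. The step from compound 1 to compound 2 concerns the chain and does not bear on it.

Compound 4 is therefore expected to lie within a modest distance of compound 2 in this assay, with the direction uncertain, as a step of a 1.5-fold lower number from compound 2 to compound 4 (0.18 log units; within the scatter). The estimate for compound 4 is 70000 nM, expected between 20000 nM and 250000 nM.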

Compound 4, half-maximal inhibitory concentration: 18700 nM
For compound 4 the middle estimate is 3.7-fold (0.57 log units) above the measured one; the whole stated range lies above it.
By their numbers in this assay, from the lowest: compounds 4 and 3 (each within the scatter of the next); then compounds 1 and 2 (each within the scatter of the next).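

In this assay, the exchange on the amine nitrogen gives a 5.6-fold lower number from compound 2 to compound 4 (0.75 log units; beyond the scatter), so a second, different group at this position moves the number beyond the scatter, and the carbonyl link need not be kept for that to happen. With the rest of the molecule fixed, compound 3 gives 25700 nM and compound 4 gives 18700 nM, values within the scatter of each other, so two quite different groups on this nitrogen, one a carbonyl with 1-methyl-1H-indol-2-yl and the other a sulfonyl with thiophen-2-yl, land at the same level, both apart from the furan-2-yl amide of compound 2. No measurement at hand accounts for this step.

The sulfonyl and the thiophene enter together, so the compounds shown leave open which of the two carries the step; a (thiophen-2-yl)carbonyl or a (furan-2-yl)sulfonyl group on the same nitrogen would separate them. Also open, on these data alone, is whether the step holds on the shorter chain of compound 1, and how a phenylsulfonyl group would read at this position.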